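Trimming the Aminohexyl Chain of an Aldehyde Dehydrogenase Inhibitor

A few compounds are considered here, and "the series" means these few. Any claim that something is new, unique, unknown or untested is made for them only; others in the source may bear on it.

Measured compounds:
compound 1 `NCCCCCCOc1ccc2c(=O)c(-c3ccc(O)cc3)coc2c1`, 100 nM
compound 2 `O=C(O)COc1ccc(-c2coc3cc(OCC(=O)O)ccc3c2=O)cc1`, >> 9000 nM
compound 3 `CCCCC(Oc1ccc2c(=O)c(-c3ccc(O)cc3)coc2c1)C(=O)OCC`, 4500 nM

All three were tested in an assay (Cricetulus griseus) for inhibition of aldehyde dehydrogenase, mitochondrial (Homo sapiens); on this read-out higher numbers stand for weaker inhibition and lower numbers for stronger inhibition. Compound 1 gives 100 nM, the lowest of the two numbers shown. Compound 3 gives 4500 nM, a number far above that of compound 1 and beyond the scatter. Compound 2 reaches only a limit of this assay, (the limit of >> 9000 nM in this assay, at which 1 of the 3 values shown sits). Compound 4 `C=CCOc1ccc2c(=O)c(-c3ccc(O)cc3)coc2c1` is not yet measured; it differs from compound 1 by vinyl in place of 5-aminopentyl on a saturated chain carbon bound to an oxygen on an aromatic ring. Among the compounds with values here, no measured pair shares this change, so the size of the step is uncertain. Compound 4 is expected to inhibit more weakly than compound 1, a step of a 10-fold higher number from compound 1 to compound 4 (1.00 log units; beyond the scatter), since compound 3 gives 4500 nM after a change on the same side chain. Compound 4 is estimated at 1000 nM, between 200 nM and 6000 nM.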

Compound 4, half-maximal inhibitory concentration: 180 nM
Estimate against measurement, compound 4: 5.6-fold (0.74 log units) above; measured number outside the range, below it.
By their numbers in this assay, from the lowest: compounds 1 and 4 (each within the scatter of the next); then compound 3. At a limit, above all of these: compound 2.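

Going from (6-aminohexyl)oxy to allyloxy gives a 1.8-fold higher number from compound 1 to compound 4 (0.26 log units; within the scatter). The amine and most of the chain of compound 1 can therefore be absent at this position with no change beyond the scatter, and compound 1 and compound 4 cannot be told apart on this read-out. Nothing measured here gives a reason for this result. The compounds shown leave open how a plain hexyl chain without the amine, or a shorter aminopropyl chain, would read, and so whether the amine and the chain length count separately.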